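A few compounds are considered here, and "the series" means these few. Any claim that something is new, unique, unknown or untested is made for them only; others in the source may bear on it.

Three compounds sharing one core have been examined in an assay on isolated protein for inhibition of Amine oxidase [flavin-containing] B (Homo sapiens), read by fluorescence; on this read-out higher numbers stand for weaker inhibition and lower numbers for stronger inhibition. Compound 1 `CC(=O)N1N=C(c2cc(O)c(O)c([N+](=O)[O-])c2)CC1c1ccco1` gives 77400 nM. Compound 2 `CC(=O)N1N=C(c2cc(O)c(O)c([N+](=O)[O-])c2)CC1c1ccc(C#N)cc1` gives 83200 nM. Compound 3 `CC(=O)N1N=C(c2cc(O)c(O)c([N+](=O)[O-])c2)CC1c1ccoc1` gives 126000 nM, the largest of the three numbers, yet the steps of a 1.5-fold higher number from compound 2 to compound 3 (0.18 log units; within the scatter) and a 1.6-fold higher number from compound 1 to compound 3 (0.21 log units; within the scatter) both sit within the scatter, so no order among the three can be claimed. The step of a 1.1-fold higher number from compound 1 to compound 2 (0.03 log units; within the scatter) is likewise within the scatter.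

Compound 4 `CC(=O)N1N=C(c2cc(O)c(O)c([N+](=O)[O-])c2)CC1c1cccc(O)c1` differs from compound 3 in the same way these three differ from one another, by exchange of the group on a saturated ring carbon: 3-hydroxyphenyl in place of furan-3-yl on a saturated ring carbon. All three measured steps concern this position, and none moved the number beyond the scatter. The expectation for compound 4 in this assay is therefore no step beyond the scatter, and the estimated step of a 1.3-fold lower number from compound 3 to compound 4 (0.10 log units; within the scatter) reflects that. Compound 4 is estimated at 100000 nM, with a range from 40000 nM to 250000 nM.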

Compound 4, half-maximal inhibitory concentration: 85200 nM
Beside the measured number, compound 4's estimate is 1.2-fold (0.07 log units) above it, within the range that was stated.
By their numbers in this assay, from the lowest: compounds 1, 2, 4 and 3 (each within the scatter of the next).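

In this assay the exchange to 3-hydroxyphenyl brings a group with 1 hydrogen-bond donor to the saturated ring carbon, where furan-3-yl has 0, and the number stays within the scatter (a 1.5-fold lower number from compound 3 to compound 4 (0.17 log units; within the scatter)). The same holds against the other two groups (a 1.0-fold higher number from compound 2 to compound 4 (0.01 log units; within the scatter); a 1.1-fold higher number from compound 1 to compound 4 (0.04 log units; within the scatter)), so with a fourth group at this position the compounds still show no order. Nothing measured here explains why the numbers stay so close.

Going by these compounds, all four groups at this position are aromatic rings, so what an amine, a carboxylic acid or a longer alkyl chain would do there remains open. Also open, on these data alone, is whether any exchange at this position can move the number beyond the scatter.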